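The compounds below may be only part of what the source reports. "The series", "measured", "known", "first", "only" and "open" are said of these compounds alone.

Three compounds on the shared core have numbers in a functional assay on GBM2 cells (Homo sapiens) for antiproliferative activity, read by WST assay, with a stated time of 72 h; a higher number here means a weaker inhibitor, a lower number a stronger inhibitor. Compound 1 (`O=C(Nc1cccc(Cl)c1)Nc1cc2ncncc2cc1OCc1ccccc1Cl`) gives 2100 nM, compound 2 (`O=C(Nc1ccc(C(F)(F)F)cc1)Nc1cc2ncncc2cc1OCc1cccc(F)c1`) gives 3200 nM and compound 3 (`O=C(Nc1cc2ncncc2cc1OCc1ccc(F)cc1)Nc1cccc2ccccc12`) gives 4500 nM. Compound 2 lies within the scatter of both compound 1 and compound 3.

Compound 4 (`O=C(Nc1ccc(Cl)c(Cl)c1)Nc1cc2ncncc2cc1OCc1cccc(F)c1`) keeps the rest of compound 2 and changes one group, with 3,4-dichlorophenyl in place of 4-(trifluoromethyl)phenyl on an amide-type nitrogen.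

Among the measured compounds shown here, no measured pair in this set differs in one place only, so the effect of this exchange in this assay cannot be read directly from the data. The measured compounds differ in more than one place, yet compound 2 at 3200 nM stays within the scatter of the other two. On that limited basis, no step beyond the scatter is expected. The estimated 1.3-fold lower number from compound 2 to compound 4 (0.11 log units; within the scatter) is expected to stay within the scatter. Compound 4 is expected at 2500 nM, with an estimated range of 1000 nM to 6000 nM.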

Compound 4, half-maximal inhibitory concentration: 1500 nM
Beside the measured number, compound 4's estimate is 1.7-fold (0.22 log units) above it, within the range that was stated.
By their numbers in this assay, from the lowest: compounds 4, 1, 2 and 3 (each within the scatter of the next, the first and the last beyond it).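

In this assay the change from 4-(trifluoromethyl)phenyl to 3,4-dichlorophenyl on the amide-type nitrogen gives a 2.1-fold lower number from compound 2 to compound 4 (0.33 log units; beyond the scatter) with the rest of the molecule unchanged, the first effect in the series that can be assigned to a single place. The earlier compounds shown here differ in more than one place and could not show that this aryl group alone moves the number, here by a modest step. Nothing available explains the step.

As far as these compounds go, whether the same exchange gives a similar step when the other substituents on the shared core differ remains open. Also open, from the compounds shown here alone, is how this position responds to a group of another kind on the amide-type nitrogen, such as an amine or a carboxylic acid on the aryl ring.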